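Halogen swap at a second ring position: outlook for compound 4

This account rests on a few compounds, and the source may have more. Where it says the series, first, only, none or still open, it means among the compounds named here.

Compound 1 `O=C(N/N=C/c1ccccc1Cl)c1cnccn1` gives 69% in an ADME assay on J774 cells (Mus musculus) for cytotoxicity, read by MTT assay, with a stated time of 48 h, tested at 150 ug/mL; on this read-out higher numbers stand for a weaker effect at the one concentration tested and lower numbers for a stronger effect. Compound 3 `O=C(N/N=C/c1ccccc1F)c1cnccn1` differs from compound 1 in a single place: fluoro in place of chloro on an aromatic carbon. In this assay compound 3 gives 81%. On this read-out the change produced a number 12 percentage points higher from compound 1 to compound 3 (beyond the scatter).

Compound 2 `O=C(N/N=C/c1ccc(Cl)cc1)c1cnccn1` has the same atoms as compound 1 joined differently; the difference between the two cores is not broken down here. In this assay compound 2 gives 56%, the lowest of the three numbers, lying beyond the scatter from both compound 1 and compound 3.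

Compound 4 `O=C(N/N=C/c1ccc(F)cc1)c1cnccn1` has not yet been measured. It differs from compound 2 thus: fluoro in place of chloro on an aromatic carbon. The surroundings are not identical: from compound 1 to compound 3 the site is ortho to a large group, from compound 2 to compound 4 it is para to a large group, so this is the same kind of change rather than the same one.

Within the data shown here, for compound 4 a step of a number 12 percentage points higher from compound 2 to compound 4 (beyond the scatter) is expected in this assay, because a number 12 percentage points higher from compound 1 to compound 3 (beyond the scatter) is the only precedent at hand and only its size is carried over. Compound 4 is accordingly estimated at 68%, within 54% to 82%, pending measurement.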

Compound 4, a percentage reported as activity, at one concentration (the size of the read-out at that concentration, not a potency): 71%
Beside the measured number, compound 4's estimate is 3 percentage points below it, within the range that was stated.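

In this assay, fluoro in place of chloro on an aromatic carbon, here para to a large group, gives a number 15 percentage points higher from compound 2 to compound 4 (beyond the scatter), which points the same way as the earlier step on the other core. The two steps cannot be told apart in size, so within these two pairs the change carries over with its direction and approximate size intact: the same change on two cores in this assay, a number 12 percentage points higher (beyond the scatter) from compound 1 to compound 3 and a number 15 percentage points higher (beyond the scatter) from compound 2 to compound 4, 3 percentage points apart, within the scatter of two such steps
This rests on two pairs at a single test concentration in one cell assay, so it shows no general rule for the series and gives no reason for the shift, and it does not separate any influence of where the halogen sits from the influence of the core.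

The compounds shown leave open whether the agreement extends beyond the two halogens to groups such as an amine, a methoxy, a carboxylic acid or a trifluoromethyl at the same ring carbon. They also leave open whether the swap would hold on a core altered elsewhere, for instance with a methyl in place of the amide hydrogen.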